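The source may report more compounds than this note shows. Statements on the series, on what has been measured and on what is new or still open speak of the compounds shown alone.

Compound 1 `O=Cc1ccc(-c2cn3ccnc3c(-c3ccc4ncn(C5CCCCC5)c4c3)n2)cc1` carries a 4-formylphenyl group on the shared core. In a functional assay on UO-31 cells (Homo sapiens) for inhibition, read by sulforhodamine B assay, with a stated time of 48 h, tested at 10 uM (on this read-out lower numbers stand for less inhibition and higher numbers for more inhibition at the one concentration tested (going by the name of the read-out)), compound 1 gives 82.2%, the highest of the three numbers. Compound 2 `Clc1ccc(-c2cn3ccnc3c(-c3ccc4ncn(C5CCCCC5)c4c3)n2)cc1` gives 36.1% and compound 3 `Fc1ccccc1-c1cn2ccnc2c(-c2ccc3ncn(C4CCCCC4)c3c2)n1` gives 22.9%. Both steps away from compound 1, a number 46.1 percentage points lower from compound 1 to compound 2 (beyond the scatter) and a number 59.3 percentage points lower from compound 1 to compound 3 (beyond the scatter), are large, while the step of a number 13.2 percentage points lower from compound 2 to compound 3 (beyond the scatter) is modest. Compound 4 `c1csc(-c2cn3ccnc3c(-c3ccc4ncn(C5CCCCC5)c4c3)n2)c1` differs from compound 1 by thiophen-2-yl in place of 4-formylphenyl on an aromatic carbon, so the 4-formylphenyl group again leaves. Each measured departure from that group brought a large fall in this assay, and a large fall in the same direction is expected here. The expected step is a number 52.2 percentage points lower from compound 1 to compound 4 (beyond the scatter). The estimated value for compound 4 is 30%, with a range from 10% to 55%.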

Compound 4, a percentage reported as inhibition, at one concentration (the size of the read-out at that concentration, not a potency): 10.9%
For compound 4 the middle estimate is 19.1 percentage points above the measured one; the measured number falls inside the stated range.
By their numbers in this assay, from the lowest: compound 4; then compound 3; then compound 2; then compound 1.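

Thiophen-2-yl gives the largest fall seen at this position in this assay (a number 71.3 percentage points lower from compound 1 to compound 4 (beyond the scatter)), so this five-membered aromatic ring does not stand in for the 4-formylphenyl group. It also ranks beneath the two other aryl groups (a number 25.2 percentage points lower from compound 2 to compound 4 (beyond the scatter); a number 12 percentage points lower from compound 3 to compound 4 (beyond the scatter)), so the fall does not depend on the 4-formylphenyl comparison alone. No evidence on the cause of this order is available. Going by these compounds, whether the high number depends on the formyl group itself remains open. A phenyl ring bearing an amine or a carboxylic acid in its place would test this.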